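Compound 2 to compound 3: cyano in place of methyl

The compounds below may be only part of what the source reports. "The series", "measured", "known", "first", "only" and "open" are said of these compounds alone.

Measured so far:
compound 1 `COC(=O)C1=C(C)N=C(C)/C(=C(/O)OC)C1c1cccc(OCCO[N+](=O)[O-])c1` gives 750 nM
compound 2 `COC(=O)C1=C(C)N=C(C)/C(=C(/O)OC)C1c1ccccc1OCc1no[n+]([O-])c1C` gives 43 nM

In a functional assay (aorta) with Rattus norvegicus as the target, in the presence of a further agent that is not named here (on this read-out higher numbers stand for an effect only at larger amounts of compound and lower numbers for an effect already at smaller amounts), compound 2 holds the lower of the two numbers, and compound 1 stands higher by a margin beyond the scatter. Among the measured compounds shown here, no step in one place links the measured compounds, so the data offer no direct precedent for the change considered next.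

Compound 3 `COC(=O)C1=C(C)N=C(C)/C(=C(/O)OC)C1c1ccccc1OCc1no[n+]([O-])c1C#N` is compound 2 with one change: cyano in place of methyl on an aromatic carbon of the five-membered aromatic ring with 2 nitrogen and 1 oxygen. The rest of the structure stays the same.

A step beyond the scatter toward a lower number is expected in this assay, although two measured compounds give only weak support for this direction. The estimated 3.6-fold lower number from compound 2 to compound 3 (0.55 log units; beyond the scatter) is therefore tentative, and the range around it is kept wide. Compound 3 is estimated at 12 nM with a range from 3 nM to 50 nM on the present evidence.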

Compound 3, half-maximal effective concentration: 4.4 nM
For compound 3 the middle estimate is 2.7-fold (0.44 log units) above the measured one, within the range that was stated.
By their numbers in this assay, from the lowest: compound 3; then compound 2; then compound 1.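

In this assay, the series now has its first step in one place: cyano in place of methyl on an aromatic carbon of the five-membered aromatic ring with 2 nitrogen and 1 oxygen gives a 9.8-fold lower number from compound 2 to compound 3 (0.99 log units; beyond the scatter). This shows that the number is sensitive to the group on this ring carbon, a point that compounds 1 and 2 could not show, as they differ in more than one place. The change swaps a methyl for a cyano that brings a triple bond and a hydrogen-bond acceptor, but no measurement here bears on which of these features, if either, goes with the lower number.

As far as these compounds go, whether the step belongs to cyano in particular remains open, since a single pair cannot show how a carboxamide, a methyl ester or an ethyl group on this ring carbon would compare with compound 3. Also open, from the compounds shown here alone, is whether the same exchange would give a step of similar size with the ring linked through a longer chain, or with a different attachment on the phenyl ring.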